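A few compounds are considered here, and "the series" means these few. Any claim that something is new, unique, unknown or untested is made for them only; others in the source may bear on it.

Compound 1 `COc1cc2c(Oc3ccc(NC(=O)NN4C(=O)CSC4c4ccc(F)cc4)cc3)ccnc2cc1OC1CCN(C(=O)NC(C)C)CC1` carries a four-fluorophenyl group on its thiazolidinone ring and an isopropyl group on the urea nitrogen of its piperidine. In a functional assay on HT-29 cells (Homo sapiens) for inhibition, read by MTT assay (a higher number here means a weaker inhibitor, a lower number a stronger inhibitor), compound 1 gives 860 nM. Among the three compounds measured so far, compound 1 gives the lowest number. Compound 2 `COc1cc2c(Oc3ccc(NC(=O)NN4C(=O)CSC4c4ccc(F)cc4)cc3)ccnc2cc1OC1CCN(C(=O)NC2CCCCC2)CC1` gives 3420 nM in this assay, and compound 3 `COc1cc2c(Oc3ccc(NC(=O)NN4C(=O)CSC4c4ccc(F)cc4)cc3)ccnc2cc1OC1CCN(C(=O)NCc2ccccc2)CC1` gives 6600 nM. The step of a 4.0-fold higher number from compound 1 to compound 2 (0.60 log units; beyond the scatter) and the step of a 7.7-fold higher number from compound 1 to compound 3 (0.89 log units; beyond the scatter) both go beyond the scatter; the step of a 1.9-fold higher number from compound 2 to compound 3 (0.29 log units; within the scatter) stays within it.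

Compound 4 `COc1cc2c(Oc3ccc(NC(=O)NN4C(=O)CSC4c4ccccc4)cc3)ccnc2cc1OC1CCN(C(=O)NC(C)C)CC1` differs from compound 1 in one place only: hydrogen in place of fluoro on an aromatic carbon. The isopropyl urea of compound 1 is kept. Going by the values given here, none of the three measured steps touches the fluorinated ring; all of them change the group on the urea nitrogen, so there is no measured step that bears on this change. The expectation is therefore a step of a 1.2-fold higher number from compound 1 to compound 4 (0.07 log units; within the scatter) that stays within the scatter, in no particular direction. Compound 4 is estimated to give 1000 nM in this assay, with a range from 400 nM to 2500 nM.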

Compound 4, half-maximal inhibitory concentration: 1260 nM
For compound 4 the middle estimate is 1.3-fold (0.10 log units) below the measured one; measured number inside the range.
By their numbers in this assay, from the lowest: compounds 1 and 4 (each within the scatter of the next); then compounds 2 and 3 (each within the scatter of the next).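

In this assay, hydrogen in place of fluoro on the aromatic carbon gives a 1.5-fold higher number from compound 1 to compound 4 (0.17 log units; within the scatter), so the fluoro and the hydrogen cannot be told apart here. Going by these compounds alone, this is the first measured change at this position, and with the isopropyl urea kept, it stays within the scatter, whereas a change on the urea nitrogen, as in a 4.0-fold higher number from compound 1 to compound 2 (0.60 log units; beyond the scatter), goes beyond it. No measurement is available that would explain this result.

The compounds shown leave open whether a chloro, methoxy or nitrile group on the same aromatic carbon would also stay within the scatter of compound 1. They also leave open whether 4-fluorophenyl to phenyl would read the same with a cyclohexyl or benzyl group on the urea nitrogen.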